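The compounds below may be only part of what the source reports. "The series", "measured", "known", "first", "only" and "open" are said of these compounds alone.

Measured so far in a functional assay on the whole organism with Mus musculus as the target, with a stated time of 15 min; on this read-out higher numbers stand for an effect only at larger amounts of compound and lower numbers for an effect already at smaller amounts:
Compound 1 `Cc1sc2c(F)cccc2c1C1C=CN=CN1` gives 10 mg/kg.
Compound 2 `Cc1sc(C2C=CN=CN2)c(C)c1C` gives 30 mg/kg.
Compound 3 `Cc1csc(C2C=CN=CN2)c1C` gives 30 mg/kg; 3 mg/kg; 3 mg/kg (3 entries).

Compound 2 stands at the highest of the two single numbers in this assay; the nearest value is that of compound 1, lower by a gap beyond the scatter. Compound 3 has repeat measurements that spread widely, as seen in the several entries of compound 3 in this assay, 30 mg/kg; 3 mg/kg; 3 mg/kg (3 entries), so a single number here carries real uncertainty. Compound 4 `Cc1c(F)sc(C2C=CN=CN2)c1C` is not yet measured; it differs from compound 2 by fluoro in place of methyl on an aromatic carbon. Among the measured compounds shown here, no measured pair shows this change, so the step is expected to be no change at the digits printed from compound 2 to compound 4 (within the scatter), none beyond the scatter. Compound 4 is therefore expected to give 30 mg/kg, within 10 mg/kg to 100 mg/kg.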

Compound 4, minimum effective dose: 10 mg/kg
Compound 4: the middle estimate sits 3.0-fold (0.48 log units) above what was measured, within the range that was stated.
By their numbers in this assay, from the lowest: compounds 1 and 4 (each within the scatter of the next); then compound 2.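

In this assay, fluoro in place of methyl on the aromatic carbon next to the ring sulfur gives a 3.0-fold lower number from compound 2 to compound 4 (0.48 log units; beyond the scatter), so this position accepts a swap of one small group for another with no loss of effect. The step is modest, and repeat entries for a single compound in this assay can spread further than this step does: the several entries of compound 3 in this assay, 30 mg/kg; 3 mg/kg; 3 mg/kg (3 entries)

The compounds shown leave open how a chloro group, a methoxy group or an amine would fare at this position.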